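The source may hold more compounds than are shown below. What is called first, only, known or untested is meant among the compounds shown, and "the series" means these compounds.

Of the compounds shown here, three built on one shared core have been tested in a functional assay on HCT-116 cells (Homo sapiens) for antiproliferative activity, read by MTT assay, with a stated time of 24 h; on this read-out lower numbers stand for stronger inhibition and higher numbers for weaker inhibition. Among the measured compounds shown here, compound 1 `COc1ccc(C(=O)/C=C/c2ccc(N(C)C)cc2)c2c1C=CC(C)(C)O2` carries a 4-(dimethylamino)phenyl on the chain, and in this assay compound 1 gives 1920 nM, the only plain number among the three. Compound 2 `COc1ccc(C(=O)/C=C/c2ccc(-c3ccccc3)cc2)c2c1C=CC(C)(C)O2` has a phenyl in place of the dimethylamino on an aromatic carbon. For compound 2 the read-out in this assay is only a limit, > 10000 nM. Compound 3 `COc1ccc(C(=O)/C=C/c2ccc(-n3ccnc3)cc2)c2c1C=CC(C)(C)O2` has a 1H-imidazol-1-yl in place of the dimethylamino on an aromatic carbon. For compound 3 the read-out in this assay is likewise a limit, > 10000 nM. Compounds 2 and 3 thus sit at the limit of > 10000 nM in this assay, at which 2 of the 3 values shown sit. The two measured steps, an at least 5.2-fold higher number from compound 1 to compound 2 (0.71 log units; beyond the scatter) and an at least 5.2-fold higher number from compound 1 to compound 3 (0.71 log units; beyond the scatter), both mean a loss of potency when the dimethylamino is gone.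

Compound 4 `COc1ccc(C(=O)/C=C/c2cccs2)c2c1C=CC(C)(C)O2` has not been measured. It differs from compound 1 as follows: thiophen-2-yl in place of 4-(dimethylamino)phenyl on a double-bonded chain carbon bound to a double-bonded chain carbon. The thiophen-2-yl brings no dimethylamino, and both measured steps away from compound 1 ran toward weaker inhibition, each at least modest in size. A step of similar direction and size is therefore expected in this assay, with a fair chance that only a limit is returned. For compound 4 the expected value is 8000 nM, within 2500 nM to 30000 nM. The expected step is a 4.2-fold higher number from compound 1 to compound 4 (0.62 log units; beyond the scatter).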

Compound 4, half-maximal inhibitory concentration: > 10000 nM
Compound 4 ended at the assay's limit; the forecaster's own chance of this, stated with the estimate: 55%; middle value at least 1.2-fold (0.09 log units) from the limit.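

Among the compounds shown here, compound 4 is the first change here that replaces the whole 4-(dimethylamino)phenyl rather than only the dimethylamino on it, and in this assay this swap gives an at least 5.2-fold higher number from compound 1 to compound 4 (0.71 log units; beyond the scatter). The entering thiophen-2-yl has 5 heavy atoms against 9 in the group that leaves, and its ring is a five-membered aromatic ring with 1 hetero atom, so weaker inhibition now appears both when the six-membered aromatic ring of carbon stays and when it is exchanged on the double-bonded chain carbon. Among the four compounds, only compound 1 gives a plain number, while the other three return limits of the assay and not numbers: the limit of > 10000 nM in this assay, at which 3 of the 4 values shown sit.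

From the compounds shown here alone, those limits cannot be read against one another, so any order among compounds 2, 3 and 4 stays unknown, and so does how far each of them truly lies from compound 1. The compounds shown also cannot tell whether another amine, such as a morpholine or a pyrrolidine, in place of the dimethylamino would keep a readable value as compound 1 does.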